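This account rests on a few compounds, and the source may have more. Where it says the series, first, only, none or still open, it means among the compounds named here.

Compound 1, `O=C(O)CCc1ccc(OCC2COc3ccc(Br)cc3O2)cc1F`, in a functional assay on HEK293 cells for agonist activity at Free fatty acid receptor 1 (Homo sapiens), read by fluorescence and calcium flux, with a stated time of 10 min (a higher number here means that more compound is needed for the effect, a lower number that less compound is needed), gives 2240 nM.
Compound 2, `O=C(O)CCc1ccc(NCC2COc3ccc(Cl)cc3O2)cc1F`, in this assay gives 13600 nM.
Compound 3, `CC#CC(CC(=O)O)c1ccc(OCC2COc3ccc(Cl)cc3O2)cc1`, in this assay gives 100 nM.

Among these three measured compounds, compound 3 stands at the lowest number, so it needs the least compound for the effect. Its nearest neighbour is compound 1, whose number is higher by a margin that lies beyond the usual scatter, and compound 2 stands furthest away with the highest number of the three, also beyond the scatter. Compound 3 therefore sits alone at the favourable end of this small set.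

Compound 4, `O=C(O)CC(c1ccc(OCC2COc3ccc(Cl)cc3O2)cc1)c1cnco1`, has not yet been measured. It differs from compound 3 in one place: 1,3-oxazol-5-yl in place of prop-1-yn-1-yl on a saturated chain carbon bound to an aromatic carbon and a saturated chain carbon. Among the compounds with values here, no pair of measured compounds shows this kind of exchange, so there is no measured step to lean on. The three measured values only show that the substituent on that saturated chain carbon can matter a great deal, since compound 3 with its prop-1-yn-1-yl group stands far below compounds 1 and 2, which lack it.

For compound 4 the expected value in this assay is estimated at 250 nM, with a likely range from 60 nM to 1000 nM. This estimate means an expected step of a 2.5-fold higher number from compound 3 to compound 4 (0.40 log units; beyond the scatter), a modest move toward a higher number that may not reach beyond the scatter.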

Compound 4, half-maximal effective concentration: 1030 nM
Estimate against measurement, compound 4: 4.1-fold (0.61 log units) below; the whole stated range lies below it.
By their numbers in this assay, from the lowest: compound 3; then compound 4; then compound 1; then compound 2.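

Exchanging prop-1-yn-1-yl for 1,3-oxazol-5-yl on a saturated chain carbon bound to an aromatic carbon and a saturated chain carbon gives in this assay a large step: a 10-fold higher number from compound 3 to compound 4 (1.01 log units; beyond the scatter). The earlier compounds shown here could only hint that this position matters, since none of them formed a one-place pair, whereas this pair shows that a single exchange here, with the rest of the molecule unchanged, moves the number well beyond the scatter. The exchange alters several things at once, as an open chain with a triple bond gives way to a five-membered aromatic ring with 2 hetero atoms, more heavy atoms and 2 hydrogen-bond acceptors, and nothing available explains which of these differences drives the step.

The compounds shown leave open whether any ring at this position gives a similar number, and a phenyl ring, which carries no hetero atoms, would separate the effect of having a ring from that of the hetero atoms. They also leave open how a small group such as methyl or ethynyl, or a plain hydrogen, would compare with prop-1-yn-1-yl on the same core.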